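The compounds below may be only part of what the source reports. "The series", "measured", "known", "first", "only" and "open" are said of these compounds alone.

Working notes on the series.

Compound 3 `Cc1ccc(-n2cc(CNC(=O)c3cccc4c3cnn4C(C)C)nn2)cc1` is the reference point for this step. In a functional assay on PC-3 cells (Homo sapiens) for inhibition, read by MTT assay, with a stated time of 72 h (on this read-out lower numbers stand for stronger inhibition and higher numbers for weaker inhibition), compound 3 gives 39000 nM, the highest number among the three measured compounds. Compound 1 `CC(C)n1ncc2c(C(=O)NCc3ccccc3)cccc21`, which carries the benzyl amide directly, gives 15200 nM in this assay. Within the data shown here, compound 2 `Cc1ccc(-n2cc(CNC(=O)c3cccc4c3cnn4C(C)C)nn2)c(C)c1` gives 10600 nM in this assay, and the single step from it to compound 3, a 3.7-fold higher number from compound 2 to compound 3 (0.57 log units; beyond the scatter), is the only step within the measured set.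

Compound 4 `CC(C)n1ncc2c(C(=O)NCc3cn(Cc4ccccc4)nn3)cccc21` is not yet measured. It differs from compound 3 as benzyl in place of 4-methylphenyl on an aromatic nitrogen. Among the measured compounds shown here, no measured pair covers this kind of rearrangement, so the step from compound 2 to compound 3 does not speak to it directly; it shows only that the neighbourhood of this ring position is sensitive in this assay. Compound 1 and compound 3, both without a methyl-bearing aryl, fall within a modest span of each other, which gives a loose anchor for a compound lacking the 4-methylphenyl altogether.

On that basis compound 4 is expected to land near compound 3, with the step of a 1.6-fold lower number from compound 3 to compound 4 (0.19 log units; within the scatter) estimated as small and of uncertain direction. The estimate for compound 4 in this assay is 25000 nM, with a range from 8000 nM to 80000 nM.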

Compound 4, half-maximal inhibitory concentration: 4420 nM
Compound 4: the middle estimate sits 5.7-fold (0.75 log units) above what was measured, outside the stated range (below it).
By their numbers in this assay, from the lowest: compound 4; then compounds 2 and 1 (each within the scatter of the next); then compound 3.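

In this assay, the group on the aromatic nitrogen of the five-membered aromatic ring with 3 nitrogen now proves to matter beyond the methyl substitution seen earlier: an 8.8-fold lower number from compound 3 to compound 4 (0.95 log units; beyond the scatter) comes from replacing 4-methylphenyl with benzyl, a change that leaves the heavy-atom count, the carbon-only six-membered aromatic ring and the hydrogen-bond donor and acceptor counts the same. Benzyl also stands below the better of the two methyl-bearing aryl groups, with a 2.4-fold lower number from compound 2 to compound 4 (0.38 log units; beyond the scatter), so among compounds 2, 3 and 4 the lowest number belongs to compound 4, and adding a methyl to the aryl ring is not the only change at this nitrogen that lowers the number. No measurement shown here accounts for these differences.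

The compounds shown leave open how a longer chain such as 2-phenylethyl, or a benzyl group carrying a methyl or a carboxylic acid on its ring, would read at this nitrogen. As far as these compounds go, it also remains open whether the methyl effect in a 3.7-fold higher number from compound 2 to compound 3 (0.57 log units; beyond the scatter) carries over to the benzyl group.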